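Chalcone series: methoxy for dimethylamino on the benzyl ring

A few compounds are considered here, and "the series" means these few. Any claim that something is new, unique, unknown or untested is made for them only; others in the source may bear on it.

Two members of the series have numbers in an assay on isolated protein for inhibition of Amine oxidase [flavin-containing] A (Homo sapiens) (a lower number here means a stronger inhibitor, a higher number a weaker inhibitor), so far. Compound 1 `CCN(CCCCCCOc1ccc(C(=O)/C=C/c2ccc(N(C)C)cc2)c(O)c1)Cc1ccccc1N(C)C` gives 37800 nM in this assay, the lowest of the two numbers. Compound 2 `CCN(CCCOc1ccc(C(=O)/C=C/c2ccc(N(C)C)cc2)c(O)c1)Cc1ccccc1` gives 82600 nM in this assay, a step beyond the scatter from compound 1; the two structures differ in more than one place, so the pair carries no single reading.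

Compound 3 `CCN(CCCCCCOc1ccc(C(=O)/C=C/c2ccc(N(C)C)cc2)c(O)c1)Cc1ccccc1OC` is the next candidate and differs from compound 1 in one place: methoxy in place of dimethylamino on an aromatic carbon. Within the data shown here, no measured pair shows this change, so the expected step from compound 1 to compound 3 in this assay rests on no direct precedent. The step from compound 1 to compound 3 is expected to be a 1.2-fold higher number from compound 1 to compound 3 (0.08 log units; within the scatter), that is, not clearly beyond the scatter. Compound 3 is estimated at 45000 nM in this assay, within a range from 15000 nM to 130000 nM.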

Compound 3, half-maximal inhibitory concentration: 54300 nM
Compound 3: the middle estimate sits 1.2-fold (0.08 log units) below what was measured; low and high end bracket the measured number.
By their numbers in this assay, from the lowest: compounds 1, 3 and 2 (each within the scatter of the next, the first and the last beyond it).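

In this assay, among these compounds, the change to methoxy in place of dimethylamino on an aromatic carbon, ortho to a large group, gives a 1.4-fold higher number from compound 1 to compound 3 (0.16 log units; within the scatter), the first reading that isolates a single place. At this position, with the chain and the shared core held as in compound 1, 2-(dimethylamino)benzyl and 2-methoxybenzyl are therefore not told apart by this measurement. No supporting data bear on why the two groups read alike here.

Open, as far as these compounds go, is whether a hydroxyl or a carboxylic acid on this aromatic carbon would separate from these two groups. Also open, from the compounds shown here alone, is whether the same exchange reads alike with a longer chain, and compound 2 cannot settle the role of the chain, as it differs from compound 1 in more than one place.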